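A Chloro-to-Fluoro Swap in a Toxicity Assay

A few compounds are considered here, and "the series" means these few. Any claim that something is new, unique, unknown or untested is made for them only; others in the source may bear on it.

In a toxicity assay on THP-1 cells (Homo sapiens) for inhibition (on this read-out lower numbers stand for higher toxicity in this test and higher numbers for lower toxicity in this test), compound 1 (`COc1ccc(-c2cnc(NC(=O)c3cnco3)n2C)cc1`) gives > 100000 nM as a limit of the assay. Compound 2 (`COc1ccc(-c2cnc(NC(=O)c3cccc(Cl)c3)n2C)cc1`) gives > 28000 nM and this too is only a limit. Among the measured compounds shown here, the one measured change is a step that the two limits leave unreadable from compound 1 to compound 2 and so offers no size to carry forward. Compound 3 (`COc1ccc(-c2cnc(NC(=O)c3cccc(F)c3)n2C)cc1`) differs from compound 2 by fluoro in place of chloro on an aromatic carbon with fluoro in place of chloro on an aromatic carbon. In this assay the expected change is a step that the limit leaves unreadable from compound 2 to compound 3 and no shift beyond the scatter is anticipated. For compound 3 the estimated value is 40000 nM with an expected range from 20000 nM to 100000 nM in this test.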

Compound 3, half-maximal cytotoxic concentration: > 100000 nM
Compound 3: a limit, no number (the forecaster's own chance of this, stated with the estimate: 70%); at least 2.5-fold (0.39 log units) between middle value and limit.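

Among the compounds shown here, compound 3 gives only a limit, as do compound 1 and compound 2, and in this assay no step among the three can be read. The compounds shown leave open where each one's actual cytotoxic concentration lies and whether they differ at all.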